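Phenyl for Benzothiazolyl: An Expected Solubility Step

The source may report more compounds than this note shows. Statements on the series, on what has been measured and on what is new or still open speak of the compounds shown alone.

Compound 1, `O=C(Nc1cccc(-c2nc3ccccc3s2)c1)c1cc([N+](=O)[O-])ccc1Cl`, in a physicochemical assay for solubility, read by spectrophotometry, in phosphate buffer, measured as kinetic solubility, with a stated time of 18 h, at pH 7.4; a lower number here means a less soluble compound, a higher number a more soluble compound: 580 nM
Compound 2, `O=C(Nc1ccc(F)c(-c2nc3ccccc3s2)c1)c1cc([N+](=O)[O-])ccc1Cl`, in this assay: 490 nM

Among the compounds with values here, compound 1 holds the highest of the two numbers measured so far; its nearest neighbour is compound 2, with a 1.2-fold lower number from compound 1 to compound 2 (0.07 log units; within the scatter), a step that sits within the scatter, so no order between the two is claimed. Compound 3, `O=C(Nc1cccc(-c2ccccc2)c1)c1cc([N+](=O)[O-])ccc1Cl`, has not yet been measured in this assay. It differs from compound 1 in one place: phenyl in place of 1,3-benzothiazol-2-yl on an aromatic carbon. Within the data shown here, the single measured step, fluoro in place of hydrogen on an aromatic carbon, leaves the 1,3-benzothiazol-2-yl group untouched and therefore offers no guide to this change. With nothing in the data bearing on it, the expected step is a 1.4-fold higher number from compound 1 to compound 3 (0.14 log units; within the scatter), a modest one carrying wide uncertainty. Compound 3 is accordingly estimated at 800 nM, in a range from 250 nM to 2500 nM.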

Compound 3, solubility: 410 nM
Estimate against measurement, compound 3: 2.0-fold (0.29 log units) above; the measured number falls inside the stated range.
By their numbers in this assay, from the lowest: compounds 3, 2 and 1 (each within the scatter of the next).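

Within the data shown here, compound 3 gives the first reading of a change at this position, an aromatic carbon meta to a large group, and in this assay the swap of 1,3-benzothiazol-2-yl for phenyl gives a 1.4-fold lower number from compound 1 to compound 3 (0.15 log units; within the scatter). That step lies within the scatter, so no order between the two compounds is claimed, even though a group of 9 heavy atoms with 2 hydrogen-bond acceptors gives way to one of 6 heavy atoms with none. Nothing available explains the reading for this pair.

As far as these compounds go, whether a group of another kind at this position, such as an amine or a carboxylic acid, would give a step beyond the scatter remains open. So does whether fluoro in place of hydrogen would give a comparable step on the phenyl series.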